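Phenyl in place of methoxymethyl on the alkyne

The compounds below may be only part of what the source reports. "The series", "measured", "known", "first", "only" and "open" are said of these compounds alone.

Measured in a functional assay on L1210 cells (Mus musculus); a higher number here means a weaker inhibitor, a lower number a stronger inhibitor:
Compound 1 `CCCCC#Cc1cn([C@H]2C[C@H](O)[C@@H](CO)O2)c(=O)[nH]c1=O` gives 1000 ug/mL.
Compound 2 `COCC#Cc1cn([C@H]2C[C@H](O)[C@@H](CO)O2)c(=O)[nH]c1=O` gives 254 ug/mL.
Compound 3 `CC#CCc1cn([C@H]2C[C@H](O)[C@@H](CO)O2)c(=O)[nH]c1=O` gives only a limit of the assay, > 1000 ug/mL.

Compound 2 has the lowest of the two numbers; its nearest neighbour is compound 1, reached by a 3.9-fold lower number from compound 1 to compound 2 (0.60 log units; beyond the scatter). Compound 4 `O=c1[nH]c(=O)n([C@H]2C[C@H](O)[C@@H](CO)O2)cc1C#Cc1ccccc1` differs from compound 2 by phenyl in place of methoxymethyl on a triple-bonded carbon. Among the compounds with values here, two measured steps bear on this: the step to compound 2 from compound 1 above, and an at least 3.9-fold higher number from compound 2 to compound 3 (0.59 log units; beyond the scatter). Both show compound 2, carrying the methoxy group, with the lowest number. Because compound 1, without that methoxy, sits at 1000 ug/mL, a rise is expected for compound 4 when the methoxymethyl leaves: a 2.4-fold higher number from compound 2 to compound 4 (0.37 log units; beyond the scatter). Compound 4 is estimated at 600 ug/mL, with a range from 200 ug/mL to 1500 ug/mL.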

Compound 4, concentration for 50% inhibition: 494 ug/mL
Estimate against measurement, compound 4: 1.2-fold (0.08 log units) above; measured number inside the range.
By their numbers in this assay, from the lowest: compounds 2 and 4 (each within the scatter of the next); then compound 1.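

On the triple-bonded carbon, the six-membered aromatic ring of phenyl serves as well as methoxymethyl in this assay, a 1.9-fold higher number from compound 2 to compound 4 (0.29 log units; within the scatter), so the oxygen of that chain is not required for a number at this level. Phenyl in place of butyl also gives a measurable gain, a 2.0-fold lower number from compound 1 to compound 4 (0.31 log units; beyond the scatter), which shows that a group without oxygen can lower the number at this position. Compound 3 gives only a limit of the assay, so its step reads as a floor, an at least 2.0-fold lower number from compound 3 to compound 4 (0.30 log units; that floor lies within the scatter).

From the compounds shown here alone, it remains open whether a phenyl ring bearing an amine or a carboxylic acid would change the number further. A pyridine ring on the alkyne also remains untested among these compounds.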